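Meta bromo for phenoxy on the arylidene ring

The compounds below may be only part of what the source reports. "The series", "measured", "known", "first", "only" and "open" are said of these compounds alone.

Working notes on three compounds sharing one core. Compound 1 `O=C1/C(=C\c2c(Cl)cccc2Cl)c2ccccc2N1c1c(Cl)cccc1Cl` carries a dichlorophenyl group on the arylidene side; in a functional assay on MOLT-4 cells (Homo sapiens) for cytotoxicity, read by MTT assay, with a stated time of 72 h (on this read-out higher numbers stand for an effect only at larger amounts of compound and lower numbers for an effect already at smaller amounts), compound 1 gives "not determined" (no result reported), so it contributes no number here. Compound 2 `O=C1/C(=C\c2cccc(Oc3ccccc3)c2)c2ccccc2N1c1c(Cl)cccc1Cl` instead bears a phenoxy group on that ring, and in this assay compound 2 gives 6 ug/mL. Within the series this is the only number available, so compound 2 cannot be ranked against any other compound; it stands alone as the single reference point.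

Compound 3 `O=C1/C(=C\c2cccc(Br)c2)c2ccccc2N1c1c(Cl)cccc1Cl` is the next member to be measured in this assay. Relative to compound 2 the change is bromo in place of phenoxy on an aromatic carbon, meta to a large group. Going by the values given here, no measured pair isolates a change of this kind, so there is no step to lean on. On the basis of compound 2 alone, the step from compound 2 to compound 3 is expected to be a 1.3-fold higher number from compound 2 to compound 3 (0.12 log units; within the scatter), not clearly beyond the scatter in either direction. For compound 3 the estimate in this assay is 8 ug/mL, with a range from 3 ug/mL to 20 ug/mL.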

Compound 3, concentration for half-maximal effect: 7 ug/mL
Beside the measured number, compound 3's estimate is 1.1-fold (0.06 log units) above it, within the range that was stated.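

In this assay, going by these compounds alone, bromo in place of phenoxy on an aromatic carbon, meta to a large group, gives a 1.2-fold higher number from compound 2 to compound 3 (0.07 log units; within the scatter), the first step that can be read. At this place, then, the carbon-only aromatic ring and the hydrogen-bond acceptor of phenoxy can leave, with a single bromine entering, and the step stays within the scatter, so this read-out does not separate the two groups. Nothing at hand gives a reason for this closeness, and the step alone cannot supply one.

Going by these compounds, with one readable pair, it remains open whether the same place would hold its read-out with an amine, a carboxylic acid or a longer alkoxy chain, and a single step does not show whether the closeness of bromo and phenoxy extends to groups of other kinds. Compound 1 gives "not determined" (no result reported), so the dichlorophenyl arylidene side stays unplaced relative to the other two compounds, and the shared core and its other aryl group remain untested by any step shown.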